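Swapping 2,4-Dimethoxyphenyl for Pyridin-2-yl on Compound 2

The compounds below may be only part of what the source reports. "The series", "measured", "known", "first", "only" and "open" are said of these compounds alone.

Within the data shown here, in an ADME assay on Vero cells (Chlorocebus sabaeus) for cytotoxicity, read by MTT assay, with a stated time of 96 h (on this read-out higher numbers stand for lower toxicity in this test and lower numbers for higher toxicity in this test), compound 2 `COc1ccc(-c2nc3cc(/C(C)=N/NC(N)=O)ccc3n2C2CCCCC2)c(OC)c1` gives 20000 nM as the only true number so far. Compound 3 `C/C(=N\NC(N)=O)c1ccc2c(c1)nc(-c1ccccn1)n2C1CCCCC1` keeps the rest of compound 2 but has pyridin-2-yl in place of 2,4-dimethoxyphenyl on an aromatic carbon. Compound 1 `CC(=O)c1ccc2c(c1)nc(-c1ccccn1)n2C1CCCCC1` also bears pyridin-2-yl and reads > 90000 nM as a limit of the assay, not a number, though it differs elsewhere too. Among the measured compounds shown here, no measured step isolates this swap, so only a modest move towards lower toxicity is expected in this assay (a 1.8-fold higher number from compound 2 to compound 3 (0.24 log units; within the scatter)). The estimate for compound 3 is 35000 nM (expected range 14000 nM to 90000 nM).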

Compound 3, half-maximal cytotoxic concentration: > 100000 nM
Compound 3 was reported as a limit; the forecaster's own chance of this, stated with the estimate: 30%; at least 2.8-fold (0.45 log units) between middle value and limit.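

In this assay, this position now has a measured step of its own: pyridin-2-yl in place of 2,4-dimethoxyphenyl gives an at least 5.0-fold higher number from compound 2 to compound 3 (0.69 log units; beyond the scatter), a change towards lower toxicity in this test. Going by these compounds, compound 3 reads > 100000 nM, which is a limit of the assay and not a number, so the full size of the step stays unknown. The step between compound 1 and compound 3 cannot be read, as both values are limits. Still open, on these data alone, is whether the ring nitrogen of pyridin-2-yl or the loss of the two methoxy groups matters more; a plain phenyl at this position would help separate the two.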